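A lone number and an iodo swap

The source may report more compounds than this note shows. Statements on the series, on what has been measured and on what is new or still open speak of the compounds shown alone.

Compound 1 `CC(=O)N[C@@H](CSC(=O)Nc1ccccc1F)C(=O)O` gives > 200000 nM
Compound 2 `COc1ccc(NC(=O)SC[C@H](NC(C)=O)C(=O)O)cc1` gives 75200 nM
Compound 3 `CC(=O)N[C@@H](CSC(=O)Nc1cccc(Cl)c1)C(=O)O` gives > 200000 nM

These values come from a functional assay on UACC-62 cells (Homo sapiens) for cytotoxicity, read by MTT assay, with a stated time of 6 days (on this read-out higher numbers stand for weaker inhibition and lower numbers for stronger inhibition), and the three compounds share one core. For compound 1 the entry > 200000 nM is a limit of the assay, not a number. For compound 3 the entry > 200000 nM is likewise a limit. For the measured compounds named here, compound 2 therefore holds the only true number of the set, at 75200 nM on the scale of measured values.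

Compound 4 `CC(=O)N[C@@H](CSC(=O)Nc1ccc(I)cc1)C(=O)O` has not yet been measured. It differs from compound 2 by iodo in place of methoxy on an aromatic carbon, para to a large group (iodo in place of methoxy on an aromatic carbon). Going by the values given here, no measured step shows what such a swap does. Compound 1 and compound 3 both stop at the limit (the limit of > 200000 nM in this assay, at which 2 of the 3 values shown sit), so the expectation in this assay leans slightly towards weaker inhibition rather than stronger. The expected step is small and may not exceed the usual scatter (a 1.2-fold higher number from compound 2 to compound 4 (0.08 log units; within the scatter)). Compound 4 is estimated at 90000 nM with 35000 nM to 200000 nM as the expected range.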

Compound 4, half-maximal inhibitory concentration: 46200 nM
Estimate against measurement, compound 4: 1.9-fold (0.29 log units) above; low and high end bracket the measured number.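

For the compounds shown here, compound 4 supplies the first step that can be read in this assay: there is a 1.6-fold lower number from compound 2 to compound 4 (0.21 log units; within the scatter). On this aromatic carbon, para to a large group, a single iodine atom can therefore take the place of the two heavy atoms of methoxy, and of its one hydrogen-bond acceptor, without a change that stands out from the scatter. With the two compounds this close, no order between them can be claimed, and this one swap is all the step describes.

Going by these compounds alone, no step to compound 1 or compound 3 can be read: the limit of > 200000 nM in this assay, at which 2 of the 4 values shown sit. Whether an amine or a nitrile on this same carbon would give a number close to those of compound 2 and compound 4 remains an open question.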